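Two Cytotoxicity Limits and an Untested Ring Swap

The source may report more compounds than this note shows. Statements on the series, on what has been measured and on what is new or still open speak of the compounds shown alone.

In an ADME assay on WI-38 cells (Homo sapiens) for cytotoxicity, read by MTT assay, with a stated time of 48 h (a lower number here means a stronger inhibitor, a higher number a weaker inhibitor), compound 1 `O=C(NCCOC(=S)Nc1ccc(F)cc1)c1cccnc1` gives > 800000 nM, which is a limit of the assay rather than a number. Compound 2 `O=C(CCCCC1CCSS1)OCCCOC(=O)c1cccnc1` stands at the same place: in this assay compound 2 gives > 800000 nM, again a limit and not a measured value. Both readings therefore sit together (the limit of > 800000 nM in this assay, at which 2 of the 2 values shown sit), so neither compound shows any measurable cytotoxicity within the tested range, and no ordering between them can be drawn.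

Compound 3 `Cc1cnc(C(=O)OCCCOC(=O)CCCCC2CCSS2)c[n+]1[O-]` has not yet been measured. It differs from compound 2 in one place (a group of 8 heavy atoms (5 carbon, 2 nitrogen, 1 oxygen; one six-membered aromatic ring with 2 hetero atoms) in place of a group of 6 heavy atoms (5 carbon, 1 nitrogen; one six-membered aromatic ring with 1 hetero atom), on a carbonyl carbon). Among the measured compounds shown here, with no measured step available for comparison, and both compounds that were tested resting at the limit, there is nothing to suggest that this change would bring the reading down into the measurable range. The expected step that the limit leaves unreadable from compound 2 to compound 3 is therefore essentially none beyond the scatter. For compound 3 in this assay the estimate is 900000 nM, within a range from 400000 nM to 2000000 nM, with the most likely outcome being that the assay again reports only a limit.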

Compound 3, half-maximal inhibitory concentration: > 800000 nM
Compound 3 gave a limit, no number (the forecaster's own chance of this, stated with the estimate: 85%); the middle value lies beyond the limit too.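

Compound 3, like compound 2, returned only a limit in this assay, so no step can be read between compound 2 and compound 3: the limit of > 800000 nM in this assay, at which 3 of the 3 values shown sit.

The compounds shown leave open where the true readings of compound 1, compound 2 and compound 3 lie, and how the group entering on the carbonyl carbon compares with pyridin-3-yl.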